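Working notes: cytotoxicity of compounds 1 to 4

This account rests on a few compounds, and the source may have more. Where it says the series, first, only, none or still open, it means among the compounds named here.

Compound 1 `CC1CCN(C2CCN(S(=O)(=O)c3cccc(-c4ccccc4F)c3)CC2)CC1` in an ADME assay on HCT-116 cells (Homo sapiens) for cytotoxicity, read by CellTiter-Glo, with a stated time of 72 h (on this read-out lower numbers stand for stronger inhibition and higher numbers for weaker inhibition), gives only a limit, > 5000 nM.
Compound 2 `Cc1cc(C)c(S(=O)(=O)N2CCC(N3CCC(O)CC3)CC2)c(C)c1` in this assay gives only a limit, > 5000 nM.
Compound 3 `Cc1cc(C)c(S(=O)(=O)N2CCC(N3CCC(Cc4ccccc4)CC3)CC2)c(C)c1` in this assay gives only a limit, > 5000 nM.

Compound 3 therefore stands at the limit of this assay, and the same holds for every measured compound here (the limit of > 5000 nM in this assay, at which 3 of the 3 values shown sit). Within the data shown here, the one single-point change among them, a step that the two limits leave unreadable from compound 2 to compound 3, cannot be read because both ends are limits; its size is unknown.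

Compound 4 `Cc1cc(C)c(S(=O)(=O)N2CCC(N3CCC(CCC#N)CC3)CC2)c(C)c1` differs from compound 3 as follows: cyanomethyl in place of phenyl on a saturated chain carbon bound to a saturated ring carbon. Among the measured compounds shown here, no measured step bears on this change with a readable size, and there is no value on the numbers side of the limit anywhere in the set from which a direction could be taken.

The expectation for compound 4 is accordingly that it, too, stays at or beyond the limit of this assay, with a step that the limit leaves unreadable from compound 3 to compound 4 that is expected to show nothing beyond the scatter. The estimate for compound 4 in this assay is 9000 nM, within 3500 nM to 40000 nM, and it is expected that the assay most likely reports only a limit again.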

Compound 4, half-maximal inhibitory concentration: > 5000 nM
Compound 4: only a limit was reported; the forecaster's own chance of this, stated with the estimate: 85%; the middle value does not contradict the limit.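

No new step can be read: compound 4 also gives only a limit in this assay, so its changes from compound 2 and from compound 3 stay unreadable, as all values sit at one limit: the limit of > 5000 nM in this assay, at which 4 of the 4 values shown sit.

The compounds shown leave open how far each lies past this limit and whether any change to the shared core gives a numerical value in this assay at all.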